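Dropping the Second Ring: From Biaryl to Bromo

A few compounds are considered here, and "the series" means these few. Any claim that something is new, unique, unknown or untested is made for them only; others in the source may bear on it.

Compound 2 `CCOC(=O)CCCCCOc1cccc(CN(C(=O)c2ccc(-c3cc(F)cc(OC)c3)cc2)C(C)C)c1` is one of two amides already tested in an ADME assay on BJ cells (Homo sapiens) for cytotoxicity, read by CellTiter-Glo and resazurin assay, with a stated time of 72 h; on this read-out lower numbers stand for an effect already at smaller amounts and higher numbers for an effect only at larger amounts of compound. For compound 2 the result is only a limit of the assay, > 26000 nM. Compound 1 `CCOC(=O)CCCCCOc1cccc(CN(C(=O)c2ccc(-c3cccc(OCC)c3)cc2)C(C)C)c1` differs from it in one place only. In this assay compound 1 likewise gives only a limit, > 22300 nM. The step that the two limits leave unreadable from compound 1 to compound 2 therefore cannot be read, as the limit of > 22300 nM in this assay, at which 1 of the 2 values shown sits, and the limit of > 26000 nM in this assay, at which 1 of the 2 values shown sits, show. Compound 3 `CCOC(=O)CCCCCOc1cccc(CN(C(=O)c2ccc(Br)cc2)C(C)C)c1` is the next member and has not yet been measured. The change is bromo in place of 3-fluoro-5-methoxyphenyl on an aromatic carbon. For the measured compounds named here, no measured step covers a change of this kind; the two values on hand show only that neither compound reached a measurable effect. The expected step from this is a step that the limit leaves unreadable from compound 2 to compound 3, meaning no movement beyond the scatter is anticipated. Compound 3 is expected to give about 30000 nM in this assay, within 10000 nM to 100000 nM, most likely again reported as a limit.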

Compound 3, half-maximal effective concentration: > 26000 nM
Compound 3 was reported as a limit; the forecaster's own chance of this, stated with the estimate: 75%; the middle value lies beyond the limit too.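

In this assay compound 3 gives only a limit, > 26000 nM. Compound 1 and compound 2 also give only limits, and the steps among these three compounds cannot be read. From the compounds shown here alone, whether any of them affects these cells at larger amounts, and how their true values compare, stays open.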